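Removing the methyl from the methoxy of compound 2

This account rests on a few compounds, and the source may have more. Where it says the series, first, only, none or still open, it means among the compounds named here.

Compound 2 `COc1cc(-c2nn(-c3cccc(NC(=O)Nc4cc(C(F)(F)F)cc(C(F)(F)F)c4)c3)cc2-c2ccncc2)ccc1Cl` gives the lowest of the three numbers in a functional assay on OVCAR-8 cells (Homo sapiens) for inhibition, read by sulforhodamine B assay, with a stated time of 48 h (on this read-out lower numbers stand for stronger inhibition of growth and higher numbers for weaker inhibition of growth), at 524 nM. Its nearest neighbour is compound 3 `COc1cc(-c2nn(-c3cccc(NC(=O)Nc4cccc(C(F)(F)F)c4)c3)cc2-c2ccncc2)ccc1Cl`, which gives 739 nM, and the two lie within the scatter, as a 1.4-fold higher number from compound 2 to compound 3 (0.15 log units; within the scatter) shows. The furthest is compound 1 `O=C(Nc1cccc(-n2cc(-c3ccncc3)c(-c3ccc(Cl)c(O)c3)n2)c1)Nc1cccc(C(F)(F)F)c1`, which gives 1570 nM, a gap beyond the scatter.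

Compound 4 `O=C(Nc1cccc(-n2cc(-c3ccncc3)c(-c3ccc(Cl)c(O)c3)n2)c1)Nc1cc(C(F)(F)F)cc(C(F)(F)F)c1` differs from compound 2 in one place: hydrogen in place of methyl on an oxygen on an aromatic ring. The measured step that bears on this is the reverse of it, from compound 1 to compound 3, where a 2.1-fold lower number from compound 1 to compound 3 (0.33 log units; beyond the scatter). Running that change backwards, the same modest size is expected in the opposite direction for compound 4 in this assay, a higher number by about the same amount. Compound 3 and compound 1 both carry the single trifluoromethyl, while compound 2 and compound 4 carry two, so the change on the oxygen and the change on the aromatic carbon never appear on the same pair of measured compounds.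

Compound 4 is therefore estimated at 1100 nM, with a range from 550 nM to 2200 nM, an expected step of a 2.1-fold higher number from compound 2 to compound 4 (0.32 log units; beyond the scatter).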

Compound 4, concentration for 50% growth inhibition: 563 nM
The estimate for compound 4 lay 2.0-fold (0.29 log units) above the measured number, within the range that was stated.
By their numbers in this assay, from the lowest: compounds 2, 4 and 3 (each within the scatter of the next); then compound 1.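

In this assay, going from methoxy to hydroxy on the 4-chloro-3-methoxyphenyl group with two trifluoromethyl groups present gives a 1.1-fold higher number from compound 2 to compound 4 (0.03 log units; within the scatter), while adding the second trifluoromethyl to the hydroxy compound 1 gives a 2.8-fold lower number from compound 1 to compound 4 (0.45 log units; beyond the scatter). The methyl on the oxygen therefore seems to count only on the compounds with one trifluoromethyl, but the two readings of this change do not separate: the same change on two cores in this assay, a 2.1-fold lower number (0.33 log units; beyond the scatter) from compound 1 to compound 3 and a 1.1-fold lower number (0.03 log units; within the scatter) from compound 4 to compound 2, 2.0-fold (0.30 log units) apart, within the scatter of two such steps. The same caution applies to the second trifluoromethyl: the same change on two cores in this assay, a 1.4-fold higher number (0.15 log units; within the scatter) from compound 2 to compound 3 and a 2.8-fold higher number (0.45 log units; beyond the scatter) from compound 4 to compound 1, 2.0-fold (0.30 log units) apart, within the scatter of two such steps.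

The compounds shown leave open how a longer chain on that oxygen, such as an ethyl or a propyl, would compare with methyl and hydrogen. They also leave open whether an amine in place of the hydroxy would give a number like that of compound 4.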